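Swapping Trifluoromethyl for Methyl on a Cyclopropane Nucleoside

A few compounds are considered here, and "the series" means these few. Any claim that something is new, unique, unknown or untested is made for them only; others in the source may bear on it.

Compound 2 `Nc1nc(OCC(F)(F)F)c2ncn(/C=C3/CC3(CO)CO)c2n1` has been tested in an ADME assay on BCBL1 cells (Homo sapiens) for cytotoxicity, with a stated time of 7 days; on this read-out lower numbers stand for higher toxicity in this test and higher numbers for lower toxicity in this test. In this assay compound 2 gives only a limit, > 20000 nM, and no measured number. Compound 1 `CNc1nc(N)nc2c1ncn2/C=C1/CC1(CO)CO` gives 67000 nM in this assay. Compound 3 `C=CCOc1nc(N)nc2c1ncn2/C=C1/CC1(CO)CO` also reaches only a limit of this assay, > 20000 nM. Two of the three values shown therefore sit at the same boundary, (the limit of > 20000 nM in this assay, at which 2 of the 3 values shown sit). None of the steps between these three compounds can be read: a step that the limit leaves unreadable from compound 1 to compound 2, a step that the limit leaves unreadable from compound 1 to compound 3, and a step that the two limits leave unreadable from compound 2 to compound 3. So the numbers shown say only that compound 1 is measurable and that compounds 2 and 3 are less toxic than the boundary of this assay.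

Compound 4 `CCOc1nc(N)nc2c1ncn2/C=C1/CC1(CO)CO` has not yet been measured. Its difference from compound 2 is methyl in place of trifluoromethyl on a saturated chain carbon bound to an oxygen on an aromatic ring. Among the compounds with values here, the one measured step that touches this part of the molecule is the exchange of vinyl for trifluoromethyl between the two compounds at the limit, and it is unreadable. With no readable step to lean on, no size or direction of change beyond the scatter is expected, and compound 2 itself stands at a limit. Compound 4 is therefore expected to sit near the same limit, with an estimated step that the limit leaves unreadable from compound 2 to compound 4. The value expected for compound 4 in this assay is 40000 nM, in a range from 15000 nM to 120000 nM.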

Compound 4, half-maximal cytotoxic concentration: > 20000 nM
Compound 4: a limit, no number; the forecaster's own chance of this, stated with the estimate: 70%; the middle value does not contradict the limit.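

Compound 4 gives only a limit in this assay, so the steps to it from compound 1, compound 2 and compound 3 cannot be read, and it joins the other compounds at one boundary: the limit of > 20000 nM in this assay, at which 3 of the 4 values shown sit.

The compounds shown leave open how far the toxicity of compound 2, compound 3 and compound 4 differs, both among themselves and from compound 1.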